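Swapping Chloro for Nitro on the Outer Ring

The source may hold more compounds than are shown below. What is called first, only, known or untested is meant among the compounds shown, and "the series" means these compounds.

Of the compounds shown here, three built on one shared core have been tested in an ADME assay on HeLa cells (Homo sapiens) for cytotoxicity; on this read-out higher numbers stand for lower toxicity in this test and lower numbers for higher toxicity in this test. Compound 1 `O=C(c1ccc([N+](=O)[O-])cc1)n1ccnc1-c1ccccc1[N+](=O)[O-]` carries a nitro group on its outer phenyl ring. In this assay compound 1 returns only a limit of the test, > 100 ug/mL, and not a number. Compound 2 `O=C(c1ccc([N+](=O)[O-])cc1)n1ccnc1-c1ccccc1Cl` has chloro in place of that nitro. In this assay compound 2 likewise returns only a limit, > 100 ug/mL. Compound 3 `O=C(c1ccc([N+](=O)[O-])cc1)n1ccnc1-c1ccc(Cl)cc1` bears a 4-chlorophenyl in place of the 2-chlorophenyl. In this assay compound 3 also returns only a limit, > 100 ug/mL. The step that the two limits leave unreadable from compound 1 to compound 2 and the step that the two limits leave unreadable from compound 2 to compound 3 therefore cannot be sized because each end rests on (the limit of > 100 ug/mL in this assay, at which 3 of the 3 values shown sit). On the numbers shown, compound 3 stands at that shared limit, neither above nor below its two companions.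

Compound 4 `O=C(c1ccc([N+](=O)[O-])cc1)n1ccnc1-c1ccc([N+](=O)[O-])cc1` differs from compound 3 by nitro in place of chloro on an aromatic carbon. Among the compounds with values here, the one measured step with a related swap, from compound 1 to compound 2, gave no readable size, so the data offer no basis for a step in either direction. The step that the limit leaves unreadable from compound 3 to compound 4 is expected to stay within the scatter. Compound 4 is therefore expected to give 150 ug/mL, within 100 ug/mL to 300 ug/mL, most likely reported again as a limit.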

Compound 4, minimum cytotoxic concentration: 100 ug/mL
The estimate for compound 4 lay 1.5-fold (0.18 log units) above the measured number; measured number inside the range.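

Within the data shown here, compound 4 is the first compound here to return an actual number rather than a limit: in this assay compound 4 gives 100 ug/mL. Compound 3, by contrast, gives only a limit of the test, > 100 ug/mL. On an aromatic carbon para to a large group, nitro in place of chloro therefore gives a number no higher from compound 3 to compound 4 (the limit leaves the size open), and neither this step nor the two earlier ones can be sized because at least one end of each rests on a limit: the limit of > 100 ug/mL in this assay, at which 3 of the 4 values shown sit.

The compounds shown leave open how far compound 3 really lies from compound 4, so whether this swap changes toxicity in this test by more than the usual scatter remains unsettled. They also leave open what an amine or a carboxylic acid would give on that same aromatic carbon in place of the nitro.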